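The compounds below may be only part of what the source reports. "The series", "measured", "known", "first", "only" and "open" are said of these compounds alone.

Measured so far in a functional assay on KB cells (Homo sapiens) for cytotoxicity; a higher number here means that more compound is needed for the effect, a lower number that less compound is needed:
- compound 1 `COC1=C(C)C(=O)/C(=C(O)/C=C/c2ccc(O)cc2)C(=O)C1(C)C`: 3.8 ug/mL
- compound 2 `COC1=C(C)C(=O)/C(=C(O)/C=C/c2cc(C)cc(C)c2)C(=O)C1(C)C`: 3.1 ug/mL

Going by the values given here, compound 2 stands within the scatter of compound 1, the only other measured compound, so the two values cannot be ranked. The next compound to be measured is compound 3 `COC1=C(C)C(=O)/C(=C(O)/C=C/c2ccco2)C(=O)C1(C)C`. Relative to compound 2, the change is furan-2-yl in place of 3,5-dimethylphenyl on a double-bonded chain carbon bound to a double-bonded chain carbon.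

Among the compounds with values here, only one measured step bears on this change, since it involves the same place: a 1.2-fold lower number from compound 1 to compound 2 (0.09 log units; within the scatter). That exchange of 4-hydroxyphenyl for 3,5-dimethylphenyl left this assay within the scatter. Within the data shown here, no measured compound carries a five-membered ring at this place, so the evidence for furan-2-yl is indirect, and the range is kept wide. No step beyond the scatter is expected in either direction. The expected change is a 1.1-fold higher number from compound 2 to compound 3 (0.05 log units; within the scatter). For compound 3 the estimated value is 3.5 ug/mL, with an expected range of 1.5 ug/mL to 8 ug/mL.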

Compound 3, concentration for half-maximal effect: 9.9 ug/mL
Compound 3: the middle estimate sits 2.8-fold (0.45 log units) below what was measured; measured number above the stated range.
By their numbers in this assay, from the lowest: compounds 2 and 1 (each within the scatter of the next); then compound 3.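

In this assay the group on a double-bonded chain carbon bound to a double-bonded chain carbon now makes a readable difference: 4-hydroxyphenyl and 3,5-dimethylphenyl stand within the scatter of each other, while furan-2-yl separates from both (a 3.2-fold higher number from compound 2 to compound 3 (0.50 log units; beyond the scatter); a 2.6-fold higher number from compound 1 to compound 3 (0.42 log units; beyond the scatter)). So the exchange between the two six-membered aromatic rings did not show how far this place tolerates change, and the first exchange to a five-membered aromatic ring with 1 hetero atom moves the number upward, meaning that more compound is needed for the effect. No measurement at hand accounts for this shift.

The exchange changes several things at once, from 8 heavy atoms to 5, from a six-membered to a five-membered ring, and from no hydrogen-bond acceptor to 1, so these three compounds cannot show which of these differences goes with the higher number. As far as these compounds go, a thiophen-2-yl ring would bear on the role of the ring oxygen and a pyridin-3-yl ring on that of a hetero atom in a six-membered ring, and how either would stand remains open.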